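A Sulfur-Bearing Group Added to Compound 1

The source may report more compounds than this note shows. Statements on the series, on what has been measured and on what is new or still open speak of the compounds shown alone.

Compound 1 `C=C1C(=O)[C@@]23C(=O)OC[C@]4([C@@H](OC(C)=O)CCC(C)(C)[C@H]4C=O)[C@@H]2CC[C@@H]1[C@H]3O` is the starting point. Within the data shown here, in a functional assay on K562 cells (Homo sapiens) for antiproliferative activity, read by MTT assay, with a stated time of 72 h (on this read-out higher numbers stand for weaker inhibition and lower numbers for stronger inhibition), compound 1 gives 8960 nM, the highest of the three numbers so far and so the weakest inhibition among them. Compound 2 `C=C1C(=O)[C@@]23C(=O)OC[C@]4(C(=O)CCC(C)(C)[C@H]4C=O)[C@@H]2CC[C@@H]1[C@H]3OC(=O)CCC(=O)Oc1ccc(-c2cc(=S)ss2)cc1` gives 1820 nM and compound 3 `C=C1C(=O)[C@@]23C(=O)OC[C@]4(C(=O)CCC(C)(C)[C@H]4C=O)[C@@H]2CC[C@@H]1[C@H]3OC(=O)c1ccccc1C(=O)Oc1ccc(-c2cc(=S)ss2)cc1` gives 4250 nM, both lower beyond the usual scatter. Each of these two carries a large group on the oxygen where compound 1 has a hydrogen, but each also differs from compound 1 elsewhere, so neither isolates that single change.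

Compound 4 `C=C1C(=O)[C@@]23C(=O)OC[C@]4([C@@H](OC(C)=O)CCC(C)(C)[C@H]4C=O)[C@@H]2CC[C@@H]1[C@H]3OC(=O)CCCCC1CCSS1` keeps the core of compound 1 and changes one place: a group of 11 heavy atoms (8 carbon, 1 oxygen, 2 sulfur; one five-membered non-aromatic ring with 2 hetero atoms) in place of a hydrogen atom, on an oxygen on a saturated carbon. A group with a five-membered non-aromatic ring with 2 hetero atoms replaces a hydrogen atom, on an oxygen on a saturated carbon. Among the measured compounds shown here, the only guides are compound 2 at 1820 nM and compound 3 at 4250 nM, so a moderate move to a lower number is expected, with the estimated step being a 2.6-fold lower number from compound 1 to compound 4 (0.41 log units; beyond the scatter). The estimate for compound 4 is 3500 nM, with an expected range of 1200 nM to 10000 nM.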

Compound 4, half-maximal inhibitory concentration: 6750 nM
Beside the measured number, compound 4's estimate is 1.9-fold (0.29 log units) below it; the range from low to high includes it.
By their numbers in this assay, from the lowest: compound 2; then compounds 3, 4 and 1 (each within the scatter of the next, the first and the last beyond it).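

Compound 4 is the only single change shown at this oxygen, and in this assay replacing the hydrogen gives a 1.3-fold lower number from compound 1 to compound 4 (0.12 log units; within the scatter) and so no shift that can be told apart from the scatter of repeated measurements. On this read-out, then, the oxygen can carry a group of 11 heavy atoms with a sulfur-containing ring and the number stays level with that of compound 1, something compound 2 and compound 3 could not show, as each also differs from compound 1 elsewhere. Nothing measured here accounts for this flat result.

One compound cannot separate the part played by the chain from that of the ring. From the compounds shown here alone, it also remains open whether a shorter chain, or a chain ending in an amine or a carboxylic acid, on this same oxygen would move the number beyond the scatter.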